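The source may report more compounds than this note shows. Statements on the series, on what has been measured and on what is new or still open speak of the compounds shown alone.

Three compounds have been measured in an assay on microsomes from liver for inhibition of sterol O-acyltransferase 1 (Rattus norvegicus); a higher number here means a weaker inhibitor, a lower number a stronger inhibitor:

Compound 1 `CCCCCCn1nc(-c2ccccc2)c(-c2ccccc2)c(C)c1=O` gives 56000 nM.
Compound 2 `O=C(O)CCCCCCn1nc(-c2ccccc2)c(-c2ccccc2)cc1=O` gives only a limit of the assay, > 300000 nM.
Compound 3 `CCCCCC(=O)Nc1cc(-c2ccccc2)c(-c2ccccc2)nn1` also gives only a limit of the assay, > 300000 nM.

For compound 3, then, no number is known, only a limit, and it shares this with one other compound: the limit of > 300000 nM in this assay, at which 2 of the 3 values shown sit. Compound 1 is the only one of the three with an actual value.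

Compound 4 `CCCCCCC[S+]([O-])c1cc(-c2ccccc2)c(-c2ccccc2)nn1` differs from compound 3 in one place: a group of 9 heavy atoms (7 carbon, 1 oxygen, 1 sulfur; no ring) in place of a group of 8 heavy atoms (6 carbon, 1 nitrogen, 1 oxygen; no ring), on an aromatic carbon. In words, a group of 9 heavy atoms (7 carbon, 1 oxygen, 1 sulfur; no ring) takes the place of a group of 8 heavy atoms (6 carbon, 1 nitrogen, 1 oxygen; no ring), on an aromatic carbon. Within the data shown here, no measured pair of compounds shows a change of this kind, so nothing here tells how large a step to expect or in which direction.

Since compound 3 sits at a limit, the step to compound 4 is estimated as a number no higher from compound 3 to compound 4 (the limit leaves the size open), which amounts to no clear change beyond the scatter. Compound 4 is accordingly expected to give about 300000 nM in this assay, within a range from 50000 nM to 1500000 nM, and may again be reported only as a limit.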

Compound 4, half-maximal inhibitory concentration: 77000 nM
Estimate against measurement, compound 4: 3.9-fold (0.59 log units) above; low and high end bracket the measured number.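

In this assay, replacing the (pentylcarbonyl)amino group on this aromatic carbon with the sulfur- and oxygen-containing chain gives an at least 3.8-fold lower number from compound 3 to compound 4 (0.59 log units; beyond the scatter). This shows that a change at this one position can bring a compound from the limit of the assay to a measurable value. The true size of this step stays open because compound 3 has no number, only a limit of the assay: the limit of > 300000 nM in this assay, at which 2 of the 4 values shown sit.

The change swaps several features at once, including the loss of the hydrogen-bond donor, so the pair cannot show which of them matters. Also open, as far as these compounds go, is whether the oxidised sulfur or the chain attached to it counts more, and a thioether, a shorter chain or an amine at this position would bear on that.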